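The source may hold more compounds than are shown below. What is called first, only, known or untested is meant among the compounds shown, and "the series" means these compounds.

Compound 1 `COc1ccc(/C=N/NC(=S)NC(C)(C)[C@H]2CC=C(C)CC2)cc1` carries a 4-methoxyphenyl group on the carbon with a double bond to nitrogen of the shared core. In a functional assay on MCF7 cells (Homo sapiens) for inhibition, read by sulforhodamine B assay, with a stated time of 48 h (a higher number here means a weaker inhibitor of growth, a lower number a stronger inhibitor of growth), compound 1 gives 31200 nM, which is the highest of the two numbers recorded so far. Its nearest neighbour, compound 2 `COc1cc(/C=N/NC(=S)NC(C)(C)[C@H]2CC=C(C)CC2)ccc1O`, gives 14800 nM in this assay, and the gap between the two lies beyond the usual scatter of repeated measurements. Compound 3 `CC1=CC[C@H](C(C)(C)NC(=S)N/N=C/c2cccc([N+](=O)[O-])c2)CC1` gives only > 100000 nM in this assay, a limit of the measurement rather than a number. Going by the values given here, it is the one compound that sits at the limit of > 100000 nM in this assay, at which 1 of the 3 values shown sits.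

Compound 4 `CC1=CC[C@H](C(C)(C)NC(=S)N/N=C/c2cccs2)CC1` has not yet been measured. It differs from compound 1 in one place: thiophen-2-yl in place of 4-methoxyphenyl on a carbon with a double bond to nitrogen. Among the compounds with values here, no pair of measured compounds shares this change, so nothing among compounds 1, 2 and 3 directly anticipates its size. The expected step in this assay, a 1.3-fold higher number from compound 1 to compound 4 (0.11 log units; within the scatter), is a modest one toward a higher number, likely no larger than the scatter itself. On that basis compound 4 is estimated at 40000 nM in this assay, with a plausible range from 10000 nM to 150000 nM, and a real chance that only a limit is reported.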

Compound 4, concentration for 50% growth inhibition: 4800 nM
Estimate against measurement, compound 4: 8.3-fold (0.92 log units) above; measured number outside the range, below it.
By their numbers in this assay, from the lowest: compound 4; then compound 2; then compound 1. At a limit, above all of these: compound 3.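

In this assay, replacing 4-methoxyphenyl with thiophen-2-yl on the carbon with a double bond to nitrogen gives a 6.5-fold lower number from compound 1 to compound 4 (0.81 log units; beyond the scatter). Compounds 1, 2 and 3 all carry a six-membered aromatic ring of carbon only at this place, so they could show only how changes on that ring read out; compound 4 shows that the ring itself can be exchanged for a five-membered aromatic ring with one hetero atom, and with fewer heavy atoms, without the number rising. No measured property among the data shown accounts for the size of this step.

The compounds shown leave open whether the lower number goes with the sulfur atom, with the five-membered ring or with the loss of the methoxy group, since all three change together in this one step. A furan-2-yl group or an unsubstituted phenyl group at this place would begin to separate these, and a thiophen-3-yl group would show whether the point of attachment on the thiophene ring matters.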